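Hydroxamate chain length on a shared core and cell inhibition

The source may hold more compounds than are shown below. What is called first, only, known or untested is meant among the compounds shown, and "the series" means these compounds.

Compounds measured in a functional assay on MDA-MB-231 cells (Homo sapiens) for inhibition, read by MTT assay, with a stated time of 72 h; a higher number here means a weaker inhibitor, a lower number a stronger inhibitor:
- compound 1, `Nc1ncnc2c1c(-c1cnc3[nH]ccc3c1)nn2CCCC(=O)NO`: > 150000 nM, which is a limit of the assay and not a number
- compound 2, `Nc1nc2cc(-c3nn(CCCCCC(=O)NO)c4ncnc(N)c34)ccc2o1`: 19000 nM
- compound 3, `Nc1ncnc2c1c(-c1cnc3[nH]ccc3c1)nn2CCCCCCCCC(=O)NO`: 11000 nM

Compound 2 gives the highest of the two numbers in this assay; compound 3 is its nearest neighbour, and that gap is within the scatter. Compound 1 only provides a limit (the limit of > 150000 nM in this assay, at which 1 of the 3 values shown sits).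

The unmeasured compound 4 is `Nc1nc2cc(-c3nn(CCCC(=O)NO)c4ncnc(N)c34)ccc2o1`. Relative to compound 2 the change is hydroxycarbamoyl in place of 2-(hydroxycarbamoyl)ethyl on a saturated chain carbon, three bonds along the chain from an aromatic nitrogen.

Within the data shown here, one measured step bears on this: the chain lengthening that gives an at least 13-fold lower number from compound 1 to compound 3 (1.13 log units; beyond the scatter). The change from compound 2 to compound 4 runs the other way, shortening the chain, so a step toward a higher number in this assay is expected, beyond the scatter, though its size is uncertain because compound 1 offers only the limit (the limit of > 150000 nM in this assay, at which 1 of the 3 values shown sits).

For compound 4 the expected result is 80000 nM, with a range from 30000 nM to 300000 nM. This estimate means a step of a 4.2-fold higher number from compound 2 to compound 4 (0.62 log units; beyond the scatter), and a limit rather than a number would not be surprising.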

Compound 4, half-maximal inhibitory concentration: 19500 nM
The estimate for compound 4 lay 4.1-fold (0.61 log units) above the measured number, and the stated range ends above it.
By their numbers in this assay, from the lowest: compounds 3, 2 and 4 (each within the scatter of the next). At a limit, above all of these: compound 1.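

In this assay, going from 5-(hydroxycarbamoyl)pentyl to 3-(hydroxycarbamoyl)propyl on the core of compound 2 leaves the number unchanged, with a 1.0-fold higher number from compound 2 to compound 4 (0.01 log units; within the scatter). On the core of compound 1, lengthening the chain gave an at least 13-fold lower number from compound 1 to compound 3 (1.13 log units; beyond the scatter), so within these compounds the sensitivity to chain length seen on that core does not appear on the core of compound 2 over this stretch of chain. With the same 3-(hydroxycarbamoyl)propyl chain as compound 4, compound 1 gives > 150000 nM, which is a limit and not a number, so at this chain length the core itself now appears to matter in this assay.

On these data alone, the size of any core effect at this chain length stays unreadable, and the step on the core of compound 1 has no exact size either: the limit of > 150000 nM in this assay, at which 1 of the 4 values shown sits. It remains open whether a longer chain, like that of compound 3, would lower the number on the core of compound 2, and whether a carboxylic acid in place of hydroxycarbamoyl would keep the values seen for compound 2 and compound 4.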